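The source may hold more compounds than are shown below. What is called first, only, known or untested is meant among the compounds shown, and "the series" means these compounds.

Series notes. The shared core of compound 1 `Cn1c(-c2ccc(NC(=O)CSc3nc4cc(Cl)ccc4o3)cc2)nc(-c2ccccc2)c1-c1ccccc1` carries an amide whose saturated chain carbon bears the varying group. In a functional assay on HT-29 cells (Homo sapiens) for cytotoxicity, read by MTT assay, with a stated time of 24 h, tested at 80 ug/mL (on this read-out lower numbers stand for a weaker effect and higher numbers for a stronger effect at the one concentration tested), compound 1 gives 79.6%. Compound 2 `CN1CCN(CC(=O)Nc2ccc(-c3nc(-c4ccccc4)c(-c4ccccc4)n3C)cc2)CC1` gives 53.1% in this assay, and compound 3 `Cn1c(-c2ccc(NC(=O)CN3CCN(c4ccccc4)CC3)cc2)nc(-c2ccccc2)c1-c1ccccc1` gives 63.7%. The measured steps are a number 26.5 percentage points lower from compound 1 to compound 2 (beyond the scatter) and a number 15.9 percentage points lower from compound 1 to compound 3 (beyond the scatter), both through exchange of the group on the saturated chain carbon bound to the carbonyl carbon, and a number 10.6 percentage points higher from compound 2 to compound 3 (beyond the scatter), through a change of the substituent on the amine nitrogen in the ring. Compound 3 thus stands second highest of the three, with compound 1 above it and compound 2 below it, both gaps beyond the scatter.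

Compound 4 `COc1ccc(CN2CCN(CC(=O)Nc3ccc(-c4nc(-c5ccccc5)c(-c5ccccc5)n4C)cc3)CC2)cc1` is not yet measured. It differs from compound 3 in one place: 4-methoxybenzyl in place of phenyl on an amine nitrogen in a ring. For the measured compounds named here, only one measured step touches the same ring nitrogen, a number 10.6 percentage points higher from compound 2 to compound 3 (beyond the scatter), and it was modest. Going by the values given here, no measured pair shows phenyl against 4-methoxybenzyl at that nitrogen; the entering group is larger and carries one hydrogen-bond acceptor, as the count shows. A step near the scatter is expected, leaning slightly downward because compound 2 with methyl on that nitrogen gave 53.1%. Compound 4 is therefore estimated at 58%, between 45% and 72%. This expectation corresponds to a number 5.7 percentage points lower from compound 3 to compound 4 (within the scatter).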

Compound 4, a percentage reported as activity, at one concentration (the size of the read-out at that concentration, not a potency): 51.2%
Compound 4: the middle estimate sits 6.8 percentage points above what was measured, and the stated range covers the measured number.
By their numbers in this assay, from the lowest: compounds 4 and 2 (each within the scatter of the next); then compound 3; then compound 1.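

For the compounds shown here, at the amine nitrogen in the ring, in this assay, the exchange of phenyl for 4-methoxybenzyl gives a number 12.5 percentage points lower from compound 3 to compound 4 (beyond the scatter), the first direct reading of these two groups at this position. The second step, a number 1.9 percentage points lower from compound 2 to compound 4 (within the scatter), places a 4-methoxyphenyl on the saturated chain carbon bound to that nitrogen, and the values of these two compounds stay within the scatter of each other. Among the three groups seen at this nitrogen, the phenyl of compound 3 therefore stands apart, while the methyl of compound 2 and the larger 4-methoxybenzyl of compound 4 both give numbers beyond the scatter below it, so the number does not follow the size of the group across these compounds.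

Nothing at hand gives a reason for this pattern, and its cause stays undetermined. Open remain the plain benzyl group, which would separate the extra chain carbon from the methoxy group, and a phenyl carrying methoxy directly on the ring, as well as whether either would hold the higher number of compound 3 at this nitrogen.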